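A few compounds are considered here, and "the series" means these few. Any claim that something is new, unique, unknown or untested is made for them only; others in the source may bear on it.

Measured so far:
compound 1, `C#CCOc1ccc(C(CC(=O)c2cccc(C)c2)CC(=O)c2cccc(C)c2)cc1OC` — > 50000 nM
compound 2, `C#CCOc1ccc(/C=C/C(=O)c2cccc(C)c2)cc1OC` — 8820 nM

In a functional assay on CCRF-CEM cells (Homo sapiens) for cytotoxicity, with a stated time of 72 h (a lower number here means a stronger inhibitor, a higher number a weaker inhibitor), compound 1 gives a limit rather than a number, > 50000 nM, which is the boundary noted in the limit of > 50000 nM in this assay, at which 1 of the 2 values shown sits. For the measured compounds named here, compound 2 holds the only actual number in this assay, 8820 nM. Compound 3, `C#CCOc1ccc(/C=C/C(=O)c2ccccc2C)cc1OC`, differs from compound 2 by 2-methylphenyl in place of 3-methylphenyl on a carbonyl carbon. Going by the values given here, no measured pair shows what such a change does, so no step beyond the scatter is expected in this assay. Compound 3 is estimated at 10000 nM, with a range from 3500 nM to 30000 nM. The expected step is a 1.1-fold higher number from compound 2 to compound 3 (0.05 log units; within the scatter).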

Compound 3, half-maximal inhibitory concentration: 6950 nM
For compound 3 the middle estimate is 1.4-fold (0.16 log units) above the measured one; low and high end bracket the measured number.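

In this assay, 2-methylphenyl in place of 3-methylphenyl on a carbonyl carbon gives a 1.3-fold lower number from compound 2 to compound 3 (0.10 log units; within the scatter) and so does not separate the two compounds. For the compounds shown here, this is the first measured step at this place, and it shows that the read-out tolerates this swap of methylphenyl groups. Nothing measured here bears on a cause for the step.

Still open, as far as these compounds go, is whether a different group on this carbonyl carbon, such as a pyridine ring or a phenyl carrying an amine or a carboxylic acid, would give a step beyond the scatter.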